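Lactone for Diol on a Terpenoid Chain: Growth Inhibition

A few compounds are considered here, and "the series" means these few. Any claim that something is new, unique, unknown or untested is made for them only; others in the source may bear on it.

Measured compounds:
Compound 1 `COC1=C[C@H](O)[C@H](C/C=C(\C)CC/C=C(\C)C[C@@H]2C[C@@H](C)C(=O)O2)[C@@H](C)C1=O` gives > 30000 nM in a functional assay on PC-3 cells (Homo sapiens) for inhibition, read by sulforhodamine B assay, with a stated time of 48 h (a lower number here means a stronger inhibitor of growth, a higher number a weaker inhibitor of growth), which is a limit of the assay.
Compound 2 `COC1=C[C@H](O)[C@H](C/C=C(\C)CC/C=C(\C)C[C@H](O)/C=C(\C)CO)[C@@H](C)C1=O` gives > 30000 nM in this assay, again only a limit.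
Compound 3 `COC1=C(OC)[C@H](OC(C)=O)[C@H](C/C=C(\C)CC/C=C(\C)C[C@H](O)/C=C(\C)CO)[C@@H](C)C1=O` gives > 30000 nM in this assay, also a limit.

Compound 2 and compound 1 differ in one place: a group of 7 heavy atoms (5 carbon, 2 oxygen; one five-membered non-aromatic ring with 1 hetero atom) in place of a group of 7 heavy atoms (5 carbon, 2 oxygen; no ring), on a saturated chain carbon bound to a double-bonded chain carbon. The step that the two limits leave unreadable from compound 2 to compound 1 cannot be read, because both sit at the limit (the limit of > 30000 nM in this assay, at which 3 of the 3 values shown sit). Compound 3 and compound 2 differ in their cores; that difference is not broken down here. Compound 4 `COC1=C(OC)[C@H](OC(C)=O)[C@H](C/C=C(\C)CC/C=C(\C)C[C@@H]2C[C@@H](C)C(=O)O2)[C@@H](C)C1=O` carries the same change on the core of compound 3: a group of 7 heavy atoms (5 carbon, 2 oxygen; one five-membered non-aromatic ring with 1 hetero atom) in place of a group of 7 heavy atoms (5 carbon, 2 oxygen; no ring), on a saturated chain carbon bound to a double-bonded chain carbon. Since compound 3 already sits at the limit and the same change left compound 2 at the limit, compound 4 is expected to remain there, an expected step that the limit leaves unreadable from compound 3 to compound 4. Compound 4 is estimated at 40000 nM, between 10000 nM and 150000 nM.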

Compound 4, concentration for 50% growth inhibition: > 30000 nM
Compound 4 ended at the assay's limit (the forecaster's own chance of this, stated with the estimate: 85%); the middle value lies beyond the limit too.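

No step from compound 3 to compound 4 can be read, because both compounds sit at a limit and not at a number: the limit of > 30000 nM in this assay, at which 4 of the 4 values shown sit.

The compounds shown leave open whether the group with the five-membered ring and the open-chain group differ in growth inhibition on either core.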